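The source may hold more compounds than are shown below. What is called first, only, known or untested is meant among the compounds shown, and "the series" means these compounds.

The shared core is that of compound 1 `O=C(NO)[C@H]1CCCCN1S(=O)(=O)N1CC=C(c2ccc(Br)cc2)CC1`, which in a functional assay on MONO-MAC-6 cells (Homo sapiens) for inhibition (a lower number here means a stronger inhibitor, a higher number a weaker inhibitor), gives 1200 nM. Compound 2 `O=C(NO)[C@H]1CCCCN1S(=O)(=O)N1CC=C(c2ccc(Oc3ccccc3)cc2)CC1` carries phenoxy in place of bromo on an aromatic carbon and in this assay gives 3300 nM; the step of a 2.8-fold higher number from compound 1 to compound 2 (0.44 log units; beyond the scatter) is the only one measured so far. Of the two numbers available, compound 1 stands lowest, with compound 2 a modest distance above it.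

Compound 3 `CCc1cccc(C2=CCN(S(=O)(=O)N3CCCC[C@@H]3C(=O)NO)CC2)c1` is not yet measured. It differs from compound 1 by 3-ethylphenyl in place of 4-bromophenyl on a double-bonded ring carbon. Going by the values given here, no measured step exchanges the whole aromatic group, so the step from compound 1 to compound 2 is the only guide: there, phenoxy in place of bromo raised the number beyond the scatter. The change to 3-ethylphenyl is of a different kind, so a step in the same direction but of similar or lesser size is expected in this assay, and an outcome within the scatter cannot be ruled out. Compound 3 is therefore estimated at 2400 nM, with a range of 800 nM to 7500 nM, which is expected to mean a 2.0-fold higher number from compound 1 to compound 3 (0.30 log units; within the scatter).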

Compound 3, half-maximal inhibitory concentration: 320 nM
Compound 3: middle estimate off by 7.5-fold (0.88 log units), on the high side; measured number below the stated range.
By their numbers in this assay, from the lowest: compound 3; then compound 1; then compound 2.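

In this assay, the group on the double-bonded ring carbon of the shared core can move the number in either direction: a 3.8-fold lower number from compound 1 to compound 3 (0.57 log units; beyond the scatter), with 3-ethylphenyl in place of 4-bromophenyl, whereas a 2.8-fold higher number from compound 1 to compound 2 (0.44 log units; beyond the scatter) with phenoxy in place of bromo. This position therefore accepts a change that lowers the number beyond the scatter, and the exchange involves no change in the counts of hydrogen-bond donors, hydrogen-bond acceptors or net charge, since both groups have none, so those counts do not distinguish the entering and leaving groups. The step combines two differences, the replacement of bromine by an ethyl chain and the change from the 4-substituted to the 3-substituted phenyl, and no measurement available here explains its direction or size.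

The compounds shown leave open how much of the step belongs to each difference, a question that 3-bromophenyl and 4-ethylphenyl would separate. Also open, on these data alone, is how the number responds at this position to a longer chain such as 3-propylphenyl, or to a phenyl group bearing an amine or a carboxylic acid.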